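This account rests on a few compounds, and the source may have more. Where it says the series, first, only, none or still open, it means among the compounds named here.

In a functional assay on MOLT-3 cells (Homo sapiens) for cytotoxicity, read by XTT assay, with a stated time of 48 h (a lower number here means a stronger inhibitor, a higher number a weaker inhibitor), compound 1 `COc1ccc(/C=C/C(=O)c2cccc(-n3cc(COc4ccc5ccc(=O)oc5c4)nn3)c2)cc1OC` gives 3120 nM. For the measured compounds named here, compound 2 `COc1cccc(/C=C/C(=O)c2cccc(-n3cc(COc4ccc5ccc(=O)oc5c4)nn3)c2)c1OC` gives 5160 nM, and the only measured step, a 1.7-fold higher number from compound 1 to compound 2 (0.22 log units; within the scatter), lies within the scatter. Compound 3 `COc1ccc(/C=C/C(=O)c2cccc(-n3cc(COc4cc(=O)oc5ccccc45)nn3)c2)cc1OC` differs from compound 1 by a group of 11 heavy atoms (9 carbon, 2 oxygen; one six-membered aromatic ring of carbon only, one six-membered aromatic ring with 1 hetero atom) in place of a group of 11 heavy atoms (9 carbon, 2 oxygen; one six-membered aromatic ring of carbon only, one six-membered aromatic ring with 1 hetero atom), on an oxygen on a saturated carbon. The two have the same atoms, joined differently. The measured step changes a different part of the molecule, so it bears on this change only indirectly, and no data show this exchange directly. No step beyond the scatter is therefore expected in this assay, and the expected step is a 1.1-fold higher number from compound 1 to compound 3 (0.05 log units; within the scatter). The estimate for compound 3 is 3500 nM, with an expected range of 1300 nM to 9500 nM.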

Compound 3, half-maximal inhibitory concentration: 3910 nM
Beside the measured number, compound 3's estimate is 1.1-fold (0.05 log units) below it; the measured number falls inside the stated range.
By their numbers in this assay, from the lowest: compounds 1, 3 and 2 (each within the scatter of the next).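

In this assay, for the compounds shown here, the exchange of the group on the oxygen on a saturated carbon for another of the same atoms, joined differently, gives a 1.3-fold higher number from compound 1 to compound 3 (0.10 log units; within the scatter) and offers the first direct reading of a change at this place. This rearrangement of the group therefore leaves the number within the scatter. No measurement at hand accounts for this result.

Still open, going by these compounds, is whether a different group at this place, such as an amine or a carboxylic acid, would move the number beyond the scatter. Also open, on these data alone, is whether the same exchange would read alike with the 2,3-dimethoxyphenyl of compound 2.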